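The source may hold more compounds than are shown below. What is called first, only, known or untested is meant among the compounds shown, and "the series" means these compounds.

In an ADME assay on HEp-2 cells (Homo sapiens) for cytotoxicity (on this read-out higher numbers stand for lower toxicity in this test and lower numbers for higher toxicity in this test), compound 1 `CC(C)CCn1c(CN2C(=O)CSc3ccccc32)nc2ccccc21` gives 6780 nM and compound 2 `O=c1c(Br)cc2ccccc2n1Cc1nc2ccccc2n1CCCCF` gives 26200 nM, the higher of the two numbers by a gap beyond the scatter. Compound 3 `CCc1cc2ccccc2n(Cc2nc3ccccc3n2CCCCF)c1=O` departs from compound 2 at one place: ethyl in place of bromo on an aromatic carbon. For the measured compounds named here, no measured pair shows this kind of change, so the expectation rests on little. No step beyond the scatter is expected in this assay, with an estimated 1.1-fold lower number from compound 2 to compound 3 (0.04 log units; within the scatter). For compound 3 the expected value is 24000 nM, with an estimated range of 10000 nM to 55000 nM.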

Compound 3, half-maximal cytotoxic concentration: 85100 nM
The estimate for compound 3 lay 3.5-fold (0.55 log units) below the measured number, and the stated range ends below it.
By their numbers in this assay, from the lowest: compound 1; then compound 2; then compound 3.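

In this assay, ethyl in place of bromo on an aromatic carbon gives a 3.2-fold higher number from compound 2 to compound 3 (0.51 log units; beyond the scatter) and so lifts the number beyond the scatter. For the compounds shown here, this is the first sign that the group at this position, two atoms from the ring nitrogen, bears on the read-out, and the step runs towards lower toxicity in this test. Going by these compounds, whether a longer chain such as propyl, or an amine or a carboxylic acid, on this carbon would move the number further stays open. No measurement at hand accounts for the step.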